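Swapping a halophenoxy group on a spiro diamino-triazine series

The source may hold more compounds than are shown below. What is called first, only, known or untested is meant among the compounds shown, and "the series" means these compounds.

The study concerns a small set of diamino-triazine spiro compounds bearing an alkoxy chain that ends in a substituted phenyl ether, examined in an assay on isolated protein for inhibition of Dihydrofolate reductase (Homo sapiens), read by spectrophotometry, using NADPH, with stated times of 5 s and 6 min, tested at 50 uM; on this read-out higher numbers stand for a stronger effect at the one concentration tested and lower numbers for a weaker effect. Compound 1, `CC(C)(C)c1ccc(OCCCON2C(N)=NC(N)=NC23CCSCC3)cc1`, carries a tert-butylphenoxy end group and in this assay compound 1 gives 86.6%. Compound 3, `NC1=NC2(CCOCC2)N(OCCCOc2ccccc2Cl)C(N)=N1`, shares the chlorophenoxy end group that the step under discussion introduces, on a core that differs from that of compound 4, and in this assay compound 3 gives 88.2%. Compound 2, `NC1=NC2(CCSCC2)N(OCCCOc2ccc(Br)cc2)C(N)=N1`, was entered in the same assay, and in this assay compound 2 gives "not determined" (no result reported), so there is no single number on which compound 2 stands; its place in the series rests only on its structure.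

Compound 4, `NC1=NC2(CCSCC2)N(OCCCOc2ccccc2Cl)C(N)=N1`, is the compound that follows from compound 2 by the change (2-chlorophenyl in place of 4-bromophenyl on an oxygen on a saturated carbon). The shared core of compounds 2 and 4 is also the core of compound 1. For the measured compounds named here, with no measured step in hand for this pair, the expectation for this assay is that compound 4 lands at a high inhibition comparable to compounds 1 and 3, with no shift beyond the scatter that can be argued from these numbers. Compound 4 is therefore expected to give about 87%, in a range from 74% to 95%.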

Compound 4, a percentage reported as inhibition, at one concentration (the size of the read-out at that concentration, not a potency): 89.6%
For compound 4 the middle estimate is 2.6 percentage points below the measured one; the range from low to high includes it.
By their numbers in this assay, from the lowest: compounds 1, 3 and 4 (each within the scatter of the next).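

In this assay, for the compounds shown here, compound 2 carries no reported result, so no step from it to compound 4 can be read. The compounds shown leave open whether 2-chlorophenyl in place of 4-bromophenyl changes inhibition on the shared core. Nothing available here offers an explanation for the value of compound 4.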